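This account rests on a few compounds, and the source may have more. Where it says the series, first, only, none or still open, it means among the compounds named here.

Compound 2 `COc1cc(-c2nn(-c3cccc(NC(=O)Nc4ccc(Cl)c(C(F)(F)F)c4)c3)cc2-c2ccncc2)ccc1Cl` carries a (4-chloro-3-(trifluoromethyl)phenyl)amino group on a carbonyl carbon. In a functional assay on SW-620 cells (Homo sapiens) for inhibition, read by sulforhodamine B assay, with a stated time of 48 h (a higher number here means that more compound is tolerated, a lower number that less compound is tolerated), compound 2 reaches only the limit > 32500 nM. Compound 1 `COc1cc(-c2nn(-c3cccc(NC(=O)c4cccc(C(F)(F)F)c4)c3)cc2-c2ccncc2)ccc1Cl` holds 3-(trifluoromethyl)phenyl at that carbonyl carbon, and in this assay compound 1 likewise stops at the limit > 50000 nM. The step that the two limits leave unreadable from compound 1 to compound 2 stays unreadable, both values being limits the limit of > 32500 nM in this assay, at which 1 of the 2 values shown sits (the limit of > 50000 nM in this assay, at which 1 of the 2 values shown sits). Compound 3 `COc1cc(-c2nn(-c3cccc(NC(=O)c4ccccc4)c3)cc2-c2ccncc2)ccc1Cl` differs from compound 2 by phenyl in place of (4-chloro-3-(trifluoromethyl)phenyl)amino on a carbonyl carbon. With both measured neighbours at limits, compound 3 is expected to show no step beyond the scatter, a step that the limit leaves unreadable from compound 2 to compound 3, and is estimated at 50000 nM, within 20000 nM to 150000 nM.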

Compound 3, concentration lethal to 50% of the cells: > 100000 nM
Compound 3: a limit, no number (the forecaster's own chance of this, stated with the estimate: 80%); at least 2.0-fold (0.30 log units) between middle value and limit.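

Compound 3 also stops at a limit, and with all three values being limits, its steps from compound 1 and from compound 2 cannot be read. The compounds shown leave open the actual lethal concentration of each compound in this assay.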